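The source may hold more compounds than are shown below. What is called first, only, known or untested is meant among the compounds shown, and "the series" means these compounds.

Measured compounds:
compound 1, `CN(C)CC1CCCc2cc(S(=O)(=O)c3ccccc3)ccc21`, 0.0631 nM
compound 2, `NC[C@@H]1CCCc2cc(S(=O)(=O)c3cccc(O)c3)ccc21`, 0.251 nM
compound 3, `O=C1CN(C[C@@H]2CCCc3cc(S(=O)(=O)c4cccc(F)c4)ccc32)CCN1`, 6.31 nM

In an assay on isolated protein for displacement of a labelled ligand from 5-hydroxytryptamine receptor 6 (Homo sapiens) (a lower number here means a stronger inhibitor, a higher number a weaker inhibitor), compound 3 stands with the highest number of the three. Its nearest neighbour is compound 2, whose number lies lower by a gap that is beyond the usual scatter, and the furthest is compound 1, lower still and again beyond the scatter. Compound 3 is therefore the weakest inhibitor of the measured set.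

Compound 4, `CN(C[C@@H]1CCCc2cc(S(=O)(=O)c3cccc(F)c3)ccc21)C(N)=O`, differs from compound 3 in a single place: carbamoyl(methyl)amino in place of 3-oxopiperazin-1-yl on a saturated chain carbon bound to a saturated ring carbon. The group that leaves brings one six-membered non-aromatic ring with two hetero atoms, one hydrogen-bond donor and two hydrogen-bond acceptors; the group that enters has no ring, one hydrogen-bond donor and one hydrogen-bond acceptor. Going by the values given here, no measured pair shows this exchange, so its effect in this assay is not known from the data. Compound 3 already gives the highest number, and the expectation is that compound 4 moves further in that direction, by a step beyond the scatter, a 6.3-fold higher number from compound 3 to compound 4 (0.80 log units; beyond the scatter). Compound 4 is estimated at 40 nM, within a range from 8 nM to 250 nM.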

Compound 4, inhibition constant: 39.8 nM
Beside the measured number, compound 4's estimate is 1.0-fold (0.00 log units) above it; the measured number falls inside the stated range.
By their numbers in this assay, from the lowest: compound 1; then compound 2; then compound 3; then compound 4.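

In this assay, going by these compounds alone, the exchange of 3-oxopiperazin-1-yl for carbamoyl(methyl)amino on a saturated chain carbon bound to a saturated ring carbon gives a 6.3-fold higher number from compound 3 to compound 4 (0.80 log units; beyond the scatter), and this is the first comparison in the set in which only one group differs while the rest of the structure stays the same. Within the data shown here, it shows that the number at this place responds to the group carried there even when both groups are uncharged and each brings one hydrogen-bond donor, although the entering group has no ring and one hydrogen-bond acceptor fewer, and the single pair cannot say which of these differences matters. No supporting measurement bears on this step.

The compounds shown leave open how a piperazine without the carbonyl, or a morpholine, would stand at this place with the rest of compound 3 unchanged. Compound 1 and compound 2 each differ from compound 3 in more than one place, so how much of their lower numbers belongs to the group at this place remains unresolved.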